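From 4-methoxyphenyl to 4-cyanophenyl on the shared core

A few compounds are considered here, and "the series" means these few. Any claim that something is new, unique, unknown or untested is made for them only; others in the source may bear on it.

In a functional assay on HT-29 cells (Homo sapiens) for inhibition, with a stated time of 72 h (a lower number here means a stronger inhibitor, a higher number a weaker inhibitor), compound 1 (`COc1ccc(S(=O)(=O)N2CCc3cccc(-c4ccc(F)nc4)c32)cc1`) gives 109 nM and compound 2 (`COc1ccc(S(=O)(=O)N2CCc3cccc(-c4ccc(N(C)C)cc4)c32)cc1`) gives 467 nM while compound 3 (`COc1ccc(-c2cccc3c2N(S(=O)(=O)c2ccc(OC)cc2)CC3)cc1`) gives 277 nM on the same read-out. Compound 3 cannot be told apart from its dimethylamino analogue (a 1.7-fold lower number from compound 2 to compound 3 (0.23 log units; within the scatter)) but stands clearly off the fluoropyridine (a 2.5-fold higher number from compound 1 to compound 3 (0.41 log units; beyond the scatter)).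

Compound 4 (`COc1ccc(S(=O)(=O)N2CCc3cccc(-c4ccc(C#N)cc4)c32)cc1`) carries cyano in place of methoxy on an aromatic carbon, para to a large group (cyano in place of methoxy on an aromatic carbon).

Going by the values given here, no measured pair makes this exact swap. The closest is the exchange at the same place of dimethylamino for methoxy, which stayed within the scatter. The two changes of the whole aryl group (a 4.3-fold higher number from compound 1 to compound 2 (0.63 log units; beyond the scatter) and the step to compound 3 above) were modest, and they are the largest seen so far. With so few points, no step beyond the scatter is expected in this assay, with only a slight lean towards a lower number (a 1.4-fold lower number from compound 3 to compound 4 (0.14 log units; within the scatter)).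

For compound 4 the estimated value is 200 nM (expected range 80 nM to 500 nM) in this assay.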

Compound 4, half-maximal inhibitory concentration: 24.2 nM
Compound 4: middle estimate off by 8.3-fold (0.92 log units), on the high side; measured number below the stated range.
By their numbers in this assay, from the lowest: compound 4; then compound 1; then compounds 3 and 2 (each within the scatter of the next).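

Going by these compounds alone, the aryl group on the shared core holds far more range than the earlier compounds showed: cyano in place of methoxy gives a large step (an 11-fold lower number from compound 3 to compound 4 (1.06 log units; beyond the scatter)), and cyano in place of dimethylamino a larger one (a 19-fold lower number from compound 2 to compound 4 (1.29 log units; beyond the scatter)), although methoxy and dimethylamino lay within the scatter of each other. Compound 4 also passes the 6-fluoropyridin-3-yl analogue (a 4.5-fold lower number from compound 1 to compound 4 (0.65 log units; beyond the scatter)), which had the lowest number until now, so its steps to all three others are beyond the scatter. No measurement at hand speaks to the reason for these steps.

Still open, as far as these compounds go, is whether the gain is specific to the nitrile or extends to other groups at this place, such as a carboxylic acid, a primary amide or trifluoromethyl. Also open, from the compounds shown here alone, is whether a pyridine ring carrying cyano instead of fluorine would go lower still.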